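The source may hold more compounds than are shown below. What is called first, only, known or untested is meant among the compounds shown, and "the series" means these compounds.

Series notes. Compound 1 `CCCNC(=O)C1C(C(=O)O)[C@@H]2CC[C@H]1O2`, compound 2 `O=C(O)C1C(C(=O)Nc2ccccc2)[C@H]2CC[C@@H]1O2` and compound 3 `Cc1cc(C)c(NC(=O)C2C(C(=O)O)[C@@H]3CC[C@H]2O3)c(C)c1` share one core and differ only in the group on the amide-type nitrogen. In an ADME assay on HT-29 cells (Homo sapiens) for cytotoxicity, read by MTT assay, with a stated time of 72 h (a lower number here means a stronger inhibitor of growth, a higher number a weaker inhibitor of growth), compound 1 gives 10000 nM, compound 2 gives 10000 nM and compound 3 gives 10000 nM. Going by the values given here, on these numbers compound 1 stands level with compounds 2 and 3; the one single-site step, no change at the digits printed from compound 1 to compound 2 (within the scatter), leaves the read-out where it was. Compound 4 `CCCCCCCCNC(=O)C1C(C(=O)O)[C@@H]2CC[C@H]1O2` is the next entry and has not yet been measured in this assay. Against compound 1 it carries the change (pentyl in place of hydrogen on a saturated chain carbon, three bonds along the chain from an amide-type nitrogen). Among the compounds with values here, no measured step lengthens the chain in this way; the nearest comparison is the swap of propyl for phenyl on the amide-type nitrogen, no change at the digits printed from compound 1 to compound 2 (within the scatter), which stayed within the scatter, and compound 3 with its trimethyl-substituted phenyl sits at the same level. On that basis no step beyond the scatter is expected from the pentyl addition: no change at the digits printed from compound 1 to compound 4 (within the scatter) is the estimated step. Compound 4 is therefore expected to give 10000 nM in this assay, within a range from 4000 nM to 25000 nM.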

Compound 4, concentration for 50% growth inhibition: 10000 nM
Compound 4: middle estimate and measured number agree at the digits printed, and the stated range covers the measured number.
By their numbers in this assay, from the lowest: compounds 1, 2, 3 and 4 (each within the scatter of the next).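

In this assay the step reads no change at the digits printed from compound 1 to compound 4 (within the scatter) for pentyl in place of hydrogen on a saturated chain carbon, three bonds along the chain from an amide-type nitrogen. The earlier step replaced propyl with phenyl on that nitrogen, whereas this one shows that the propyl chain of compound 1 also takes an added pentyl of 5 heavy atoms, with no ring, and the read-out stays level with the rest of the series. No measured evidence accounts for this flat read-out.

The compounds shown leave open whether an amine or a hydroxyl on this saturated chain, or a chain longer than that of compound 4, would separate from this level. They also leave open how a methyl ester in place of the carboxylic acid on the shared core would read.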